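Second fluoro on the aryl urea of compound 2

The compounds below may be only part of what the source reports. "The series", "measured", "known", "first", "only" and "open" are said of these compounds alone.

The series is three aryl ureas on a shared core. In an ADME assay on the whole organism with Oryza sativa as the target, tested at 0.1 uM (on this read-out lower numbers stand for a stronger effect and higher numbers for a weaker effect at the one concentration tested), compound 1 `Cc1ccccc1NC(=O)N[C@@H](C)c1ccccc1` gives 100%, compound 2 `C[C@H](NC(=O)Nc1ccccc1F)c1ccccc1` gives 98% and compound 3 `C[C@H](NC(=O)Nc1cccc(F)c1F)c1ccccc1` gives 100%. Compound 2 holds the lowest of the three numbers, yet both neighbours lie within the scatter of it: a number 2 percentage points lower from compound 1 to compound 2 (within the scatter) and a number 2 percentage points higher from compound 2 to compound 3 (within the scatter). Compound 4 `C[C@H](NC(=O)Nc1cc(F)ccc1F)c1ccccc1` differs from compound 2 by fluoro in place of hydrogen on an aromatic carbon. For the measured compounds named here, the only measured step of the same kind, fluoro in place of hydrogen on an aromatic carbon, is the one from compound 2 to compound 3, which stayed within the scatter; the step from compound 1 to compound 2 adds nothing beyond that. For compound 4 the expected change in this assay is a number 1 percentage points higher from compound 2 to compound 4 (within the scatter), none beyond the scatter. The estimate for compound 4 is 99%, within 90% to 100%.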

Compound 4, a percentage reported as activity, at one concentration (the size of the read-out at that concentration, not a potency): 100%
Beside the measured number, compound 4's estimate is 1 percentage points below it, and the stated range covers the measured number.
By their numbers in this assay, from the lowest: compounds 2, 1, 3 and 4 (each within the scatter of the next).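

With a second fluoro in a new place, meta to a large group and para to a fluoro group, the read-out gives a number 2 percentage points higher from compound 2 to compound 4 (within the scatter) in this assay. Alongside a number 2 percentage points higher from compound 2 to compound 3 (within the scatter), this means that both fluoro-for-hydrogen steps from compound 2 stay within the scatter, so neither placement separates from the other. Nothing available explains this flat result.

The aryl substituents shown are only methyl and fluoro, so it remains open whether any group there can move the read-out beyond the scatter. An amine or a carboxylic acid at this position would test that.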